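Triazole series: swapping the aryl arm on the core

This account rests on a few compounds, and the source may have more. Where it says the series, first, only, none or still open, it means among the compounds named here.

Compound 1 `COc1ccccc1-c1ncnn1-c1cc(OC)c(OC)c(OC)c1` is the starting point. In a functional assay on Jurkat cells (Homo sapiens) for antiproliferative activity, read by MTT assay, with a stated time of 72 h (on this read-out higher numbers stand for weaker inhibition and lower numbers for stronger inhibition), compound 1 gives > 10000 nM, which is a limit of the assay and not a number. Compound 2 `COc1cc(-c2ncnn2-c2cccc([N+](=O)[O-])c2)cc(OC)c1OC` gives > 10000 nM in this assay, again a limit. Compound 3 `CCOc1ccccc1-c1ncnn1-c1cc(OC)c(OC)c(OC)c1` gives > 10000 nM in this assay, likewise a limit. For the measured compounds named here, all three values rest at the limit of > 10000 nM in this assay, at which 3 of the 3 values shown sit, so compound 1 cannot be ordered against either companion, and the one step between compounds that differ in a single place, a step that the two limits leave unreadable from compound 1 to compound 3, is therefore without a readable size.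

Compound 4 `COc1cc(-n2ncnc2-c2ccc(SC)cc2)cc(OC)c1OC` differs from compound 1 as follows: 4-(methylsulfanyl)phenyl in place of 2-methoxyphenyl on an aromatic carbon. Going by the values given here, no measured step touches this change, and the only evidence from compound 1 and its two companions is the shared limit, which sets a ceiling on compound 1 and nothing more. The step of an at least 12-fold lower number from compound 1 to compound 4 (1.09 log units; beyond the scatter) is thus an expectation only, and a move toward stronger inhibition is taken as possible rather than supported. Compound 4 is expected in this assay at 800 nM, within a range from 60 nM to 10000 nM, with a real chance that only a limit is reported once more.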

Compound 4, half-maximal inhibitory concentration: 50 nM
Compound 4: the middle estimate sits 16-fold (1.20 log units) above what was measured; measured number below the stated range.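

The aryl arm on the aromatic carbon of the five-membered ring turns out to be a place where one change gives a readable result: in this assay, 4-(methylsulfanyl)phenyl in place of 2-methoxyphenyl gives an at least 200-fold lower number from compound 1 to compound 4 (2.30 log units; beyond the scatter), although the two arms match in heavy atoms, hydrogen-bond donors and hydrogen-bond acceptors. From the compounds shown here alone, compound 1 gives > 10000 nM, which is a limit and not a number, so the step marks a minimum size and its full size stays unknown. Compound 4 is the only one of the four compounds shown that comes off the limit: the limit of > 10000 nM in this assay, at which 3 of the 4 values shown sit.

The change replaces both the atom joining the group to the phenyl ring and the group's place on that ring, so the compounds shown cannot say which of the two carries the step; a phenyl arm with methoxy at the place the methylsulfanyl group holds in compound 4 would separate them. Also open, going by these compounds, is how much the sulfur group itself tolerates change, for example a longer chain such as ethylsulfanyl or an oxidised form such as methylsulfonyl.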